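Series notes: acrylamide warhead swap across two pyrimidine cores

The source may hold more compounds than are shown below. What is called first, only, known or untested is meant among the compounds shown, and "the series" means these compounds.

Compound 1 `C=C(Cl)C(=O)Nc1cc(Nc2ncc(C#N)c(-c3cn(C)c4ccccc34)n2)c(OC)cc1N(C)CCN(C)C` carries a 1-chloroethenyl group on the carbonyl carbon of its amide, and in a functional assay on HepG2 cells (Homo sapiens) for antiproliferative activity, read by MTT assay, with a stated time of 72 h (on this read-out higher numbers stand for weaker inhibition and lower numbers for stronger inhibition), compound 1 gives 115 nM. Compound 2 `CC/C=C\C(=O)Nc1cc(Nc2ncc(C#N)c(-c3cn(C)c4ccccc34)n2)c(OC)cc1N(C)CCN(C)C` differs only in the warhead, (but-1-en-1-yl in place of 1-chloroethenyl on a carbonyl carbon), and in this assay compound 2 gives 1360 nM. The step is a 12-fold higher number from compound 1 to compound 2 (1.07 log units; beyond the scatter), so on this core the swap costs a good deal of potency.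

Compound 3 `C=C(Cl)C(=O)Nc1cc(Nc2nc(C)cc(-c3cn(C)c4ccccc34)n2)c(OC)cc1N(C)CCN(C)C` keeps the 1-chloroethenyl warhead of compound 1 but sits on a different core; the difference between the two cores is not broken down here. In this assay compound 3 gives 3640 nM, the highest number of the three measured, beyond the scatter from both compound 2 and compound 1.

Compound 4 `CC/C=C\C(=O)Nc1cc(Nc2nc(C)cc(-c3cn(C)c4ccccc34)n2)c(OC)cc1N(C)CCN(C)C` is the companion of compound 3 in the same way that compound 2 is the companion of compound 1: the change is but-1-en-1-yl in place of 1-chloroethenyl on a carbonyl carbon, made at the same place. Within the data shown here, only one example of this change has been measured, so any expectation leans on that single step. The step from compound 3 to compound 4 is expected to be a 4.9-fold higher number from compound 3 to compound 4 (0.69 log units; beyond the scatter), resting on the step of a 12-fold higher number from compound 1 to compound 2 (1.07 log units; beyond the scatter), and a somewhat compressed step is allowed for because compound 3 gives 3640 nM, already a high starting point. Compound 4 is therefore estimated at 18000 nM, between 6000 nM and 60000 nM, with some chance that this assay reports only a limit for it.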

Compound 4, half-maximal inhibitory concentration: 2050 nM
Estimate against measurement, compound 4: 8.8-fold (0.94 log units) above, outside the stated range (below it).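

In this assay, but-1-en-1-yl in place of 1-chloroethenyl on the carbonyl carbon gives a 1.8-fold lower number from compound 3 to compound 4 (0.25 log units; within the scatter), so the two groups are not told apart on the core of compound 3. The large step seen on the core of compound 1 therefore does not carry over to the core of compound 3, and the size of this change depends on the core it is made on: the same change on two cores in this assay, a 12-fold higher number (1.07 log units; beyond the scatter) from compound 1 to compound 2 and a 1.8-fold lower number (0.25 log units; within the scatter) from compound 3 to compound 4, 21-fold (1.32 log units) apart, beyond the scatter of two such steps. Among these compounds, this rests on only two matched pairs, so it sets no rule for any further core and does not show which feature of the two cores goes with the difference, nor why the 1-chloroethenyl compounds part so widely while the but-1-en-1-yl pair does not.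

Going by these compounds, it remains open how a plain ethenyl group, or a but-1-en-1-yl chain ending in a dimethylamino group, would behave on the carbonyl carbon of either core. Also open, on these data alone, is whether the same dependence on the core would appear with such groups, or whether it belongs to this one pair of groups alone.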